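The compounds below may be only part of what the source reports. "The series", "measured", "known", "first", "only" and "open" are said of these compounds alone.

Among the compounds with values here, compound 2 `CCCc1nc(-c2ccccc2)c(CNCCN2CCN(c3cccc(C)c3C)CC2)o1` is one of only two compounds measured in an assay on HEK293 cells for inhibition of Voltage-dependent T-type calcium channel subunit alpha-1G (Homo sapiens), read by fluorescence, tested at 10 uM; on this read-out lower numbers stand for less inhibition and higher numbers for more inhibition at the one concentration tested (going by the name of the read-out). Compound 2 gives 66.7%, while compound 1 `CCCc1nc(-c2ccccc2)c(CNCCN2CCN(c3ccccc3Cl)CC2)o1` gives 60.1%; the step of a number 6.6 percentage points higher from compound 1 to compound 2 (within the scatter) lies within the scatter, so the two sit side by side rather than apart. Compound 3 `CCCc1nc(-c2ccccc2)c(CNCCN2CCN(c3ccccn3)CC2)o1` differs from compound 2 by pyridin-2-yl in place of 2,3-dimethylphenyl on an amine nitrogen in a ring. Within the data shown here, the single step that bears on this change, from compound 1 to compound 2, stayed within the scatter, so no step beyond the scatter is expected here either. Compound 3 is therefore estimated at 55%, with a range from 30% to 80%, which is expected to mean a step of a number 11.7 percentage points lower from compound 2 to compound 3 (beyond the scatter).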

Compound 3, a percentage reported as inhibition, at one concentration (the size of the read-out at that concentration, not a potency): 48.1%
The estimate for compound 3 lay 6.9 percentage points above the measured number; the measured number falls inside the stated range.
By their numbers in this assay, from the lowest: compound 3; then compounds 1 and 2 (each within the scatter of the next).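

Placing pyridin-2-yl on the amine nitrogen in the ring is the first change at this position to move this assay beyond the scatter, giving a number 18.6 percentage points lower from compound 2 to compound 3 (beyond the scatter) and also a number 12 percentage points lower from compound 1 to compound 3 (beyond the scatter). The two rings of carbon only thus sit apart from the ring that holds a nitrogen, though not from each other. Nothing available explains this difference. A plain phenyl group or a pyridin-3-yl group at this position could show whether the lower number goes with the ring nitrogen, its location, or the absence of the chloro or methyl groups.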